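The source may hold more compounds than are shown below. What is called first, only, known or untested is meant among the compounds shown, and "the series" means these compounds.

Compound 2 `Cn1ccc2c(Oc3ccc(NC(=O)c4nn(-c5ccccc5)ccc4=O)cc3)ccnc21` has the higher of the two numbers measured in a functional assay on HepG2 cells (Homo sapiens) for cytotoxicity, read by MTT assay, with a stated time of 72 h; a higher number here means a weaker inhibitor, a lower number a stronger inhibitor: compound 2 gives 56200 nM, while compound 1 `O=C(Nc1ccc(Oc2ccnc3[nH]ccc23)cc1)c1nn(-c2ccc(Cl)c(C(F)(F)F)c2)ccc1=O` gives 1320 nM, a gap well beyond the scatter. Compound 3 `Cn1ccc2c(Oc3ccc(NC(=O)c4nn(-c5ccc(Cl)c(C(F)(F)F)c5)ccc4=O)cc3)ccnc21` differs from compound 2 by 4-chloro-3-(trifluoromethyl)phenyl in place of phenyl on an aromatic nitrogen. Among the measured compounds shown here, no measured pair isolates this change, so its size is uncertain; still, the substituted aryl is the one carried by compound 1, whose 1320 nM suggests a move toward stronger inhibition. He expects a sizeable downward step a 16-fold lower number from compound 2 to compound 3 (1.21 log units; beyond the scatter) in this assay. For compound 3 he estimates 3500 nM, within 800 nM to 15000 nM.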

Compound 3, half-maximal inhibitory concentration: 23400 nM
The estimate for compound 3 lay 6.7-fold (0.83 log units) below the measured number, outside the stated range (above it).
By their numbers in this assay, from the lowest: compound 1; then compound 3; then compound 2.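

In this assay, 4-chloro-3-(trifluoromethyl)phenyl in place of phenyl on the aromatic nitrogen gives a 2.4-fold lower number from compound 2 to compound 3 (0.38 log units; beyond the scatter) and so accounts for only a modest change at this position. Methyl in place of hydrogen on an aromatic nitrogen of the core gives a much larger change, an 18-fold higher number from compound 1 to compound 3 (1.25 log units; beyond the scatter) in the same assay. Nothing available explains either step.

The compounds shown leave open whether the aryl change would have the same size with hydrogen on that core nitrogen. They also leave open how an aryl group carrying an amine or a carboxylic acid would behave at this position.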